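Aryl in place of hydroxy on the shared core

This account rests on a few compounds, and the source may have more. Where it says the series, first, only, none or still open, it means among the compounds named here.

Three compounds on one core have numbers in an assay for binding affinity to Neuronal acetylcholine receptor; alpha4/beta2 (Rattus norvegicus); a lower number here means a stronger inhibitor, a higher number a weaker inhibitor. Compound 1 `COc1ccc(-c2cnc3cc4c(cc3n2)C2CNCC4C2)cc1` gives 26 nM. Compound 2 `c1cc(-c2cnc3cc4c(cc3n2)C2CNCC4C2)c[nH]1` gives 360 nM; the move is a 14-fold higher number from compound 1 to compound 2 (1.14 log units; beyond the scatter). For compound 3 `Oc1cnc2cc3c(cc2n1)C1CNCC3C1` the assay reports only a limit, < 6 nM, so compound 3 stands at the limit of < 6 nM in this assay, at which 1 of the 3 values shown sits, and its exact position is not fixed. The steps onto it are an at least 4.3-fold lower number from compound 1 to compound 3 (0.63 log units; beyond the scatter) and an at least 60-fold lower number from compound 2 to compound 3 (1.77 log units; beyond the scatter); both are beyond the scatter, and both point to the hydroxy compound as the stronger end of the three.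

Compound 4 `Clc1ccc(-c2cnc3cc4c(cc3n2)C2CNCC4C2)cc1` is not yet measured. The change from compound 3 is 4-chlorophenyl in place of hydroxy on an aromatic carbon. The nearest measured step is the reverse kind, where hydroxy in place of 4-methoxyphenyl gave an at least 4.3-fold lower number from compound 1 to compound 3 (0.63 log units; beyond the scatter); the pyrrolyl step an at least 60-fold lower number from compound 2 to compound 3 (1.77 log units; beyond the scatter) was larger. A 4-chlorophenyl sits closer to the methoxyphenyl of compound 1 than to the pyrrolyl of compound 2, so the expected step is upward and of modest size, an at least 5.0-fold higher number from compound 3 to compound 4 (0.69 log units; beyond the scatter). Compound 4 is estimated at 30 nM, with a range of 8 nM to 120 nM.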

Compound 4, inhibition constant: 78 nM
Beside the measured number, compound 4's estimate is 2.6-fold (0.41 log units) below it; the range from low to high includes it.
By their numbers in this assay, from the lowest: compound 1; then compound 4; then compound 2. At a limit, below all of these: compound 3.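

In this assay, 4-chlorophenyl on this aromatic carbon, next to the ring nitrogen, again stands on the weaker side of hydroxy, an at least 13-fold higher number from compound 3 to compound 4 (1.11 log units; beyond the scatter), so all three aromatic rings shown at this position give higher numbers than hydroxy. The value of compound 3 is a limit: the limit of < 6 nM in this assay, at which 1 of the 4 values shown sits. The aromatic ring itself also matters, since chloro in place of methoxy gives a 3.0-fold higher number from compound 1 to compound 4 (0.48 log units; beyond the scatter) and 4-chlorophenyl in place of 1H-pyrrol-3-yl gives a 4.6-fold lower number from compound 2 to compound 4 (0.66 log units; beyond the scatter), both modest steps.

Open, on these data alone, is how a small non-ring group at this position, such as an amine or a short alkyl chain, would compare with hydroxy. Also open, as far as these compounds go, is how a carboxylic acid on the phenyl ring would compare with chloro and methoxy.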